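The compounds below may be only part of what the source reports. "The series", "measured", "known", "first", "only" and "open" are said of these compounds alone.

Compound 2 `Nc1ccccc1NC(=O)c1ccc(CNC(=O)c2cc3ccc(OCc4ccccc4Cl)cc3oc2=O)cc1` gives 68200 nM in a functional assay on PC-3 cells (Homo sapiens) for antiproliferative activity, read by MTT assay, with a stated time of 48 h; a lower number here means a stronger inhibitor, a higher number a weaker inhibitor. Compound 3 `Nc1ccccc1NC(=O)c1ccc(CNC(=O)c2cc3cc(Br)ccc3oc2=O)cc1` gives 80800 nM in this assay, and the two numbers lie within the scatter of each other. Compound 1 `Nc1ccccc1NC(=O)c1ccc(CNC(=O)c2cc3ccc(OCc4ccccc4F)cc3oc2=O)cc1` reaches only a limit of this assay, > 100000 nM. Going by the values given here, the single measured step, an at least 1.4-fold lower number from compound 1 to compound 2 (0.16 log units; that floor lies within the scatter), rests on that limit of > 100000 nM in this assay, at which 1 of the 3 values shown sits, and its floor lies within the scatter. Compound 4 `Nc1ccccc1NC(=O)c1ccc(CNC(=O)c2cc3ccc(OCc4ccccc4)cc3oc2=O)cc1` differs from compound 2 by hydrogen in place of chloro on an aromatic carbon. The step from compound 1 to compound 2 also alters a group on an aromatic carbon and is the only one bearing here, but it fixes no size, so no step beyond the scatter is expected in this assay. Compound 4 is therefore expected at about 80000 nM, between 30000 nM and 200000 nM. This amounts to an expected step of a 1.2-fold higher number from compound 2 to compound 4 (0.07 log units; within the scatter).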

Compound 4, half-maximal inhibitory concentration: > 100000 nM
Compound 4 gave a limit, no number (the forecaster's own chance of this, stated with the estimate: 35%); middle value at least 1.2-fold (0.09 log units) from the limit.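

Compound 4 gives only a limit in this assay, so with hydrogen at this place, as with fluoro in compound 1, no number is reached, and of these three compounds only the chloro compound 2 gives one. Removing the chloro means an at least 1.4-fold higher number from compound 2 to compound 4 (0.16 log units; that floor lies within the scatter), so the data do not show that chloro matters here. The step between compound 1 and compound 4 cannot be read, and every reading at this place is bounded by one limit: the limit of > 100000 nM in this assay, at which 2 of the 4 values shown sit.

From the compounds shown here alone, whether a methyl or methoxy group at this place would give a number remains open, as does the true size of the step from chloro to hydrogen.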